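Adenine-side chain swap: from chlorobutenyl to hydroxybutenyl

The source may report more compounds than this note shows. Statements on the series, on what has been measured and on what is new or still open speak of the compounds shown alone.

Values in a functional assay on L1210 cells (Mus musculus) for inhibition; on this read-out lower numbers stand for stronger inhibition and higher numbers for weaker inhibition:
compound 1 `Nc1ncnc2c1ncn2C/C=C/CCl` gives 45000 nM
compound 2 `Nc1ccn(C=C=CCO)c(=O)n1` gives 560000 nM
compound 3 `Nc1ccn(CC#CCO)c(=O)n1` gives > 550000 nM

Compound 1 (45000 nM) has the lower of the two numbers available. Compound 2 (560000 nM) is its nearest neighbour, and this higher number lies beyond the scatter. Compound 3 gives > 550000 nM as a limit and not a number.

Compound 4 (`Nc1ncnc2c1ncn2/C=C/CCO`) shares the core of compound 1 and carries 4-hydroxybut-1-en-1-yl in place of 4-chlorobut-2-en-1-yl on an aromatic nitrogen. Among the measured compounds shown here, no step between measured compounds that differ in one place is available, so the expectation rests on weak ground. Compound 2 has a different core but, like compound 4, carries a hydroxy group. Compound 2 gives 560000 nM, which points towards weak inhibition. A clear step to a higher number in this assay, beyond the scatter, is therefore expected. The expected step is a 5.6-fold higher number from compound 1 to compound 4 (0.74 log units; beyond the scatter) in this direction. Compound 4 is estimated at 250000 nM with an expected range from 70000 nM to 700000 nM in this assay on this read-out.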

Compound 4, half-maximal inhibitory concentration: 100000 nM
For compound 4 the middle estimate is 2.5-fold (0.40 log units) above the measured one; low and high end bracket the measured number.
By their numbers in this assay, from the lowest: compound 1; then compound 4; then compound 2.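

Among the compounds shown here, on the shared core, the change on the aromatic nitrogen gives the first readable step: in this assay, 4-hydroxybut-1-en-1-yl in place of 4-chlorobut-2-en-1-yl gives a 2.2-fold higher number from compound 1 to compound 4 (0.35 log units; beyond the scatter), a modest step. Inhibition therefore does not depend on the chlorine of compound 1, since compound 4 keeps a measurable value of 100000 nM with a hydroxy group at the chain end and one hydrogen-bond donor and one acceptor that the chlorobutenyl chain lacks. The value of compound 4 is a number and not a limit, which sets it apart from the one limit in the series: the limit of > 550000 nM in this assay, at which 1 of the 4 values shown sits.

The step combines the swap of chlorine for hydroxy with a different place for the chain's double bond, and the compounds shown do not divide it between the two, which a 4-hydroxybut-2-en-1-yl chain on the shared core would do. Also open, on these data alone, is how an amine or a carboxylic acid at the chain end, or a longer chain, would read in this assay.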